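A few compounds are considered here, and "the series" means these few. Any claim that something is new, unique, unknown or untested is made for them only; others in the source may bear on it.

Working notes on the series. In a functional assay on THP-1 cells (Homo sapiens) for inhibition, read by sulforhodamine B assay, with a stated time of 48 h, tested at 50 uM (on this read-out higher numbers stand for more inhibition of growth at the one concentration tested and lower numbers for less inhibition of growth), compound 1 `COc1cc(/C=C/C(=O)/C=C/c2cc(OC)c(OC)c(OC)c2)ccc1OCc1cn(CCCCOc2cc(=O)oc3ccccc23)nn1` gives 65%. Compound 2 `COc1cc(/C=C/C(=O)/C=C/c2cccs2)ccc1OCc1cn(CCCCOc2cc(=O)oc3ccccc23)nn1` carries thiophen-2-yl in place of 3,4,5-trimethoxyphenyl on a double-bonded chain carbon bound to a double-bonded chain carbon relative to compound 1, and in this assay compound 2 gives 44%, so that the step of a number 21 percentage points lower from compound 1 to compound 2 (beyond the scatter). Compound 3 `COc1cc(/C=C/C(=O)/C=C/c2cc(OC)c(OC)c(OC)c2)ccc1OCc1cn(CCCOc2cc(=O)oc3ccccc23)nn1` gives 79% in this assay, the highest of the three values; the difference between the cores of compound 1 and compound 3 is not broken down here. Compound 4 `COc1cc(/C=C/C(=O)/C=C/c2cccs2)ccc1OCc1cn(CCCOc2cc(=O)oc3ccccc23)nn1` is not yet measured; it differs from compound 3 by thiophen-2-yl in place of 3,4,5-trimethoxyphenyl on a double-bonded chain carbon bound to a double-bonded chain carbon, the same change as from compound 1 to compound 2, made at the same place. A step of similar size is expected from compound 3 to compound 4, a number 21 percentage points lower from compound 3 to compound 4 (beyond the scatter), because the same change gave a number 21 percentage points lower from compound 1 to compound 2 (beyond the scatter) in the measured pair. For compound 4 the expected value in this assay is 58%, with a range from 45% to 70%.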

Compound 4, percent growth inhibition at one concentration: 54%
Compound 4: the middle estimate sits 4 percentage points above what was measured; the measured number falls inside the stated range.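

In this assay, thiophen-2-yl in place of 3,4,5-trimethoxyphenyl again lowers the number, giving a number 25 percentage points lower from compound 3 to compound 4 (beyond the scatter). The change carries over between these two cores with no difference in step size: the same change on two cores in this assay, a number 21 percentage points lower (beyond the scatter) from compound 1 to compound 2 and a number 25 percentage points lower (beyond the scatter) from compound 3 to compound 4, 4 percentage points apart, within the scatter of two such steps. Among these compounds, this rests on only two pairs, read at one concentration in one cell line, so it does not show that the step would hold on other cores or in other assays, nor does it explain the drop.

The compounds shown leave open how other groups would behave at this place, such as a 4-aminophenyl or a 4-carboxyphenyl group on a double-bonded chain carbon bound to a double-bonded chain carbon. Also open, on these data alone, is whether the step persists on a core with a longer chain.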